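The source may report more compounds than this note shows. Statements on the series, on what has been measured and on what is new or still open speak of the compounds shown alone.

Compound 2 `O=C1/C(=N\NC(=S)Nc2ccc(Cl)cc2)c2cc(Br)ccc2N1Cc1ccc(F)cc1` gives 61000 nM in a functional assay on CCRF-CEM cells (Homo sapiens), with a stated time of 72 h; a higher number here means a weaker inhibitor, a lower number a stronger inhibitor. Among the two numbers so far that is the highest, and its nearest neighbour is compound 1 `O=C1/C(=N\NC(=S)Nc2ccc(Cl)cc2)c2cc(F)ccc2N1Cc1ccc(F)cc1`, which in this assay gives 56000 nM; the step of a 1.1-fold higher number from compound 1 to compound 2 (0.04 log units; within the scatter) lies within the scatter. Compound 3 `O=C1/C(=N\NC(=S)Nc2ccc(Cl)cc2)c2cc(Br)ccc2N1Cc1ccc(Cl)cc1` follows from compound 2 by chloro in place of fluoro on an aromatic carbon. Among the measured compounds shown here, the only measured step that bears on a halogen swap on an aromatic carbon is the one from compound 1 to compound 2, which was within the scatter, although it sits on the shared core rather than on the benzyl group. On that basis the step of a 1.0-fold lower number from compound 2 to compound 3 (0.01 log units; within the scatter) is expected to stay within the scatter, with no clear direction. Compound 3 is therefore estimated at 60000 nM in this assay, in a range from 30000 nM to 120000 nM.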

Compound 3, half-maximal inhibitory concentration: 392000 nM
Compound 3: the middle estimate sits 6.5-fold (0.82 log units) below what was measured, and the stated range ends below it.
By their numbers in this assay, from the lowest: compounds 1 and 2 (each within the scatter of the next); then compound 3.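

On the benzyl group, at an aromatic carbon para to a large group, chloro in place of fluoro is not a neutral halogen swap in this assay: the change gives a 6.4-fold higher number from compound 2 to compound 3 (0.81 log units; beyond the scatter), toward a weaker inhibitor. The earlier halogen step on the shared core, a 1.1-fold higher number from compound 1 to compound 2 (0.04 log units; within the scatter), stayed within the scatter, but the two steps differ both in place and in the halogen that enters, so they do not show which of these matters. Nothing available gives a reason for this loss of activity.

The compounds shown leave open whether the change from 4-fluorobenzyl to 4-chlorobenzyl would have the same size with fluoro instead of bromo on the shared core. They also leave open how an unsubstituted benzyl group, or a methoxy group or an amine at this place, would read in this assay.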